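Second methyl on the phenoxy ring of compound 2

The compounds below may be only part of what the source reports. "The series", "measured", "known", "first", "only" and "open" are said of these compounds alone.

Measured compounds:
compound 1, `Cc1cc(C(=O)c2ccccc2)ccc1OCC(=O)Nc1nc(-c2ccccc2)cs1`, 22300 nM
compound 2, `COc1ccc(-c2csc(NC(=O)COc3ccc(C(=O)c4ccccc4)cc3C)n2)cc1`, 27100 nM
compound 3, `COc1ccc(-c2csc(NC(=O)COc3ccc(C(=O)c4ccc(C)cc4)cc3C)n2)cc1`, 19400 nM

In a functional assay on Ehrlich cells (Mus musculus) for cytotoxicity, read by trypan blue exclusion, with a stated time of 48 h (on this read-out lower numbers stand for stronger inhibition and higher numbers for weaker inhibition), compound 2 gives the highest of the three numbers, but its distance to the others is small: from compound 1 the step is a 1.2-fold higher number from compound 1 to compound 2 (0.08 log units; within the scatter), and from compound 3 it is a 1.4-fold lower number from compound 2 to compound 3 (0.15 log units; within the scatter), both within the scatter. Compound 4, `COc1ccc(-c2csc(NC(=O)COc3c(C)cc(C(=O)c4ccccc4)cc3C)n2)cc1`, is obtained from compound 2 by methyl in place of hydrogen on an aromatic carbon.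

Within the data shown here, the one measured step that resembles this change is the one from compound 2 to compound 3, in which a methyl also replaces a hydrogen on an aromatic carbon, there on the benzoyl group, and which came out as a 1.4-fold lower number from compound 2 to compound 3 (0.15 log units; within the scatter). The step from compound 1 to compound 2, another single substituent added to an aromatic ring, was likewise a 1.2-fold higher number from compound 1 to compound 2 (0.08 log units; within the scatter). Neither step moved the number beyond the scatter, so for compound 4 no step beyond the scatter is expected in this assay in either direction. Compound 4 is therefore estimated at 25000 nM, within a range of 12000 nM to 50000 nM. The step this implies from compound 2 to compound 4, a 1.1-fold lower number from compound 2 to compound 4 (0.04 log units; within the scatter), is expected to stay within the scatter.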

Compound 4, half-maximal inhibitory concentration: 40600 nM
Compound 4: the middle estimate sits 1.6-fold (0.21 log units) below what was measured; the measured number falls inside the stated range.
By their numbers in this assay, from the lowest: compounds 3, 1, 2 and 4 (each within the scatter of the next, the first and the last beyond it).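

In this assay, among these compounds, the added methyl gives a 1.5-fold higher number from compound 2 to compound 4 (0.18 log units; within the scatter), which is the first measured change on the phenoxy ring, at a carbon ortho to a large group, meta to a benzoyl group and meta to a methyl group. Until now, the measured changes had been on the other aromatic rings, among them the methyl on the benzoyl group in a 1.4-fold lower number from compound 2 to compound 3 (0.15 log units; within the scatter), and compound 4 now shows that a methyl on the phenoxy ring also leaves the number within the scatter of compound 2, so the three single changes shown on these aromatic rings have all stayed within it. No measurement offered here bears on why this position behaves as it does.

Whether a larger or charged group at this carbon, such as a methoxy, an amine or a carboxylic acid, would move the number beyond the scatter remains open, since methyl is the only group shown there. Going by these compounds, it is also open whether this methyl would give a similar step on the methylbenzoyl scaffold of compound 3 or on the unsubstituted phenyl scaffold of compound 1.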